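A few compounds are considered here, and "the series" means these few. Any claim that something is new, unique, unknown or untested is made for them only; others in the source may bear on it.

In an assay on isolated protein for binding affinity to Gonadotropin-releasing hormone receptor (Rattus norvegicus) (on this read-out higher numbers stand for weaker inhibition and lower numbers for stronger inhibition), the measured compounds are:

compound 1 `Cc1cc2c(cc1Cc1ccc(C(=O)NCC3CCCCC3)o1)C(C)(C)CCC2(C)C`: 1550 nM
compound 2 `Cc1cc2c(cc1Cc1ccc(C(=O)NCC3CCC(CN)CC3)o1)C(C)(C)CCC2(C)C`: 730 nM
compound 3 `Cc1cc2c(cc1Cc1ccc(C(=O)NCC3CCCC(CN)C3)o1)C(C)(C)CCC2(C)C`: 890 nM

Compound 1 gives the highest of the three numbers, though its gap to compound 3 is within the scatter. The change to compound 4 `Cc1cc2c(cc1Cc1ccc(C(=O)NCC3CCN(C(=N)N)CC3)o1)C(C)(C)CCC2(C)C` is a group of 9 heavy atoms (6 carbon, 3 nitrogen; one six-membered non-aromatic ring with 1 hetero atom) in place of a group of 6 heavy atoms (6 carbon; one six-membered non-aromatic ring of carbon only), on a saturated chain carbon bound to an amide-type nitrogen. Among the measured compounds shown here, two measured steps bear on it, each adding aminomethyl in place of hydrogen on a saturated ring carbon: a 2.1-fold lower number from compound 1 to compound 2 (0.33 log units; beyond the scatter), and a 1.7-fold lower number from compound 1 to compound 3 (0.24 log units; within the scatter). Only the first lies beyond the scatter, so such additions bring at most a modest gain. Compound 4 is therefore expected to show a modest decrease of similar size, a 2.4-fold lower number from compound 1 to compound 4 (0.38 log units; beyond the scatter). For compound 4 the estimate in this assay is 650 nM, with a range from 250 nM to 1700 nM.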

Compound 4, inhibition constant: 2040 nM
Estimate against measurement, compound 4: 3.1-fold (0.50 log units) below; measured number outside the range, above it.
By their numbers in this assay, from the lowest: compounds 2, 3, 1 and 4 (each within the scatter of the next, the first and the last beyond it).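

At this position, on a saturated chain carbon bound to an amide-type nitrogen, replacing cyclohexyl with the larger group carrying hydrogen-bond donors brings no measurable gain in this assay (a 1.3-fold higher number from compound 1 to compound 4 (0.12 log units; within the scatter)). The aminomethyl compounds give lower numbers (a 2.3-fold higher number from compound 3 to compound 4 (0.36 log units; beyond the scatter); a 2.8-fold higher number from compound 2 to compound 4 (0.45 log units; beyond the scatter)), so adding nitrogen to this group does not by itself lower the number. No measurement shown here accounts for this difference.

Still open, going by these compounds, is how a carboxylic acid on the cyclohexyl ring, or a longer chain between that ring and the amide nitrogen, would read here. These compounds also do not separate the effect of the ring nitrogen from that of the group it carries.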